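A few compounds are considered here, and "the series" means these few. Any claim that something is new, unique, unknown or untested is made for them only; others in the source may bear on it.

Measured so far in a functional assay on Hep cells (Homo sapiens) for cytotoxicity, read by sulforhodamine B assay, with a stated time of 48 h; a higher number here means a weaker inhibitor, a lower number a stronger inhibitor:
compound 1 `CC1=C(/C=C/C(=O)/C=C/c2ccc(C)cc2)C(C)(C)CCC1`: 44100 nM
compound 2 `CC1=C(/C=C/C(=O)/C=C/c2ccccc2Cl)C(C)(C)CCC1`: 54200 nM
compound 3 `CC1=C(/C=C/C(=O)/C=C/c2ccccc2F)C(C)(C)CCC1`: 23600 nM

Going by the values given here, compound 3 gives the lowest of the three numbers, but only one of its steps is beyond the scatter: a 2.3-fold lower number from compound 2 to compound 3 (0.36 log units; beyond the scatter) is modest, while a 1.9-fold lower number from compound 1 to compound 3 (0.27 log units; within the scatter) is within the scatter, as is a 1.2-fold higher number from compound 1 to compound 2 (0.09 log units; within the scatter). The three values therefore sit in a narrow band.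

The next compound, compound 4 `CC1=C(/C=C/C(=O)/C=C/c2ccccc2C)C(C)(C)CCC1`, differs from compound 3 by methyl in place of fluoro on an aromatic carbon. Among the compounds with values here, two measured steps bear on this. The swap of one group for another at the same aromatic carbon, a 2.3-fold lower number from compound 2 to compound 3 (0.36 log units; beyond the scatter), moved the number only modestly. The exchange of a 4-methylphenyl for a 2-fluorophenyl, a 1.9-fold lower number from compound 1 to compound 3 (0.27 log units; within the scatter), stayed within the scatter. Within the data shown here, nothing measured so far separates a methyl from a halogen at this position, so a step in either direction of more than the scatter is not expected; a number close to that of compound 3, or somewhat higher towards compound 1, is the estimate, which would mean a 1.4-fold higher number from compound 3 to compound 4 (0.13 log units; within the scatter). Compound 4 is therefore expected to give about 32000 nM in this assay, with a range from 14000 nM to 75000 nM.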

Compound 4, half-maximal inhibitory concentration: 41000 nM
The estimate for compound 4 lay 1.3-fold (0.11 log units) below the measured number; the measured number falls inside the stated range.
By their numbers in this assay, from the lowest: compounds 3, 4, 1 and 2 (each within the scatter of the next, the first and the last beyond it).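

In this assay, methyl on this aromatic carbon, ortho to a large group, cannot be told apart from fluoro (a 1.7-fold higher number from compound 3 to compound 4 (0.24 log units; within the scatter)) or from chloro (a 1.3-fold lower number from compound 2 to compound 4 (0.12 log units; within the scatter)), even though the two halogens are separated from each other (a 2.3-fold lower number from compound 2 to compound 3 (0.36 log units; beyond the scatter)). The 2-methylphenyl and 4-methylphenyl compounds also cannot be told apart (a 1.1-fold lower number from compound 1 to compound 4 (0.03 log units; within the scatter)), so the methyl reads the same in both of the placements shown. No measurement at hand accounts for any of these numbers.

Still open, as far as these compounds go, is whether any group on this aromatic carbon, such as an amine, a carboxylic acid or a methoxy group, would move the number well outside this narrow band. From the compounds shown here alone, all four compounds carry the shared core unchanged, so its contribution also remains open.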